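A few compounds are considered here, and "the series" means these few. Any claim that something is new, unique, unknown or untested is made for them only; others in the source may bear on it.

Of the compounds shown here, two from this series have been tested in a functional assay on HFF cells (Homo sapiens) for cytotoxicity; a higher number here means that more compound is tolerated, a lower number that less compound is tolerated. Compound 1, with the structure `C=CCOc1nc(N)nc2c1ncn2/C=C1/C[C@@H]1CO`, gives 220000 nM in this assay. Compound 2, with the structure `Nc1nc(NC2CC2)c2ncn(/C=C3/C[C@@H]3CO)c2n1`, gives 213000 nM in this assay. Within the data shown here, compound 2 therefore holds the lower of the two numbers, but its nearest neighbour is compound 1, and the one step recorded between them, a 1.0-fold lower number from compound 1 to compound 2 (0.01 log units; within the scatter), is too small to count as a real difference.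

Compound 3, with the structure `C=CCNc1nc(N)nc2c1ncn2/C=C1/C[C@@H]1CO`, has not yet been measured. It differs from compound 2 in one place: allyl in place of cyclopropyl on a nitrogen on an aromatic ring. Among the measured compounds shown here, the only measured step that bears on this change is the one from compound 1 to compound 2, which exchanged a group on the same aromatic carbon and left the number essentially unchanged. For the measured compounds named here, the two compounds measured so far sit at almost the same level, so there is no reason in these data to expect a shift beyond the scatter when cyclopropyl gives way to allyl on that nitrogen.

The estimate for compound 3 in this assay is 215000 nM, with a range from 100000 nM to 450000 nM. The step from compound 2 to compound 3 is therefore expected to be a 1.0-fold higher number from compound 2 to compound 3 (0.00 log units; within the scatter).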

Compound 3, half-maximal cytotoxic concentration: > 368000 nM
Compound 3: only a limit was reported; the forecaster's own chance of this, stated with the estimate: 10%; middle value at least 1.7-fold (0.23 log units) from the limit.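

Compound 3 yields no exact number in this assay, only a limit: the limit of > 368000 nM in this assay, at which 1 of the 3 values shown sits. With allyl in place of cyclopropyl on the nitrogen, the result is an at least 1.7-fold higher number from compound 2 to compound 3 (0.23 log units; that floor lies within the scatter), and with allylamino in place of allyloxy on the aromatic carbon, it is an at least 1.6-fold higher number from compound 1 to compound 3 (0.22 log units; that floor lies within the scatter). Both figures are floors that do not clear the scatter, so neither establishes a real difference, but the earlier pair gave two exact numbers, whereas this swap of a ring for an open chain with the same carbon count gives a value with no upper bound, so the true gap could be small or much larger.

From the compounds shown here alone, with only a limit for compound 3, the size of both steps stays unknown, and whether an open allyl chain on this nitrogen truly differs from a cyclopropyl ring cannot be read from these three compounds. Going by these compounds, it also remains open how this assay would respond to a longer chain on the same nitrogen, or to a carboxylic acid or a plain amine on the same aromatic carbon.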